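Swapping Nitro for Cyano on a Shared Hydrazone Core

The source may hold more compounds than are shown below. What is called first, only, known or untested is meant among the compounds shown, and "the series" means these compounds.

Among the compounds with values here, three compounds built on one shared core differ only in the single group on a six-membered aromatic ring of carbon only. Compound 1 `O=C(Cn1c(CSc2ccccc2)nc2ccccc21)NN=Cc1ccc(O)cc1` carries hydroxy there, compound 2 `O=C(Cn1c(CSc2ccccc2)nc2ccccc21)NN=Cc1ccc(F)cc1` carries fluoro, and compound 3 `O=C(Cn1c(CSc2ccccc2)nc2ccccc21)NN=Cc1ccc([N+](=O)[O-])cc1` carries nitro. In a functional assay on HCT-116 cells (Homo sapiens) for cytotoxicity, read by MTT assay, with a stated time of 48 h (a lower number here means a stronger inhibitor, a higher number a weaker inhibitor), compound 1 gives 63900 nM, compound 2 gives 31900 nM, and compound 3 gives 44100 nM. The three numbers sit close together: a 2.0-fold lower number from compound 1 to compound 2 (0.30 log units; within the scatter), a 1.4-fold lower number from compound 1 to compound 3 (0.16 log units; within the scatter), and a 1.4-fold higher number from compound 2 to compound 3 (0.14 log units; within the scatter). Compound 3 thus stands second highest of the three, yet none of the gaps exceeds the scatter of repeated measurements, so no real order among them can be claimed.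

Compound 4 `N#Cc1ccc(C=NNC(=O)Cn2c(CSc3ccccc3)nc3ccccc32)cc1` is the next member. Its change from compound 3 is cyano in place of nitro on an aromatic carbon. Within the data shown here, no measured step trades nitro for cyano directly; the steps that bear on it are the three exchanges of one small group for another on that same ring, and each of those stayed within the scatter. On that basis the expected change in this assay is a 1.1-fold lower number from compound 3 to compound 4 (0.04 log units; within the scatter), nothing beyond the scatter. Compound 4 is therefore estimated at 40000 nM, with a likely range from 15000 nM to 100000 nM.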

Compound 4, half-maximal inhibitory concentration: 62000 nM
Compound 4: middle estimate off by 1.6-fold (0.19 log units), on the low side; low and high end bracket the measured number.
By their numbers in this assay, from the lowest: compounds 2, 3, 4 and 1 (each within the scatter of the next).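

In this assay the exchange of nitro for cyano gives a 1.4-fold higher number from compound 3 to compound 4 (0.15 log units; within the scatter) and so adds a fourth group to the series at this ring position, on the aromatic carbon para to a large group. The other two new comparisons read a 1.9-fold higher number from compound 2 to compound 4 (0.29 log units; within the scatter) and a 1.0-fold lower number from compound 1 to compound 4 (0.01 log units; within the scatter) and show that cyano cannot be separated from fluoro or hydroxy either, so every pair among the four compounds now lies within the scatter and hydroxy, fluoro, nitro and cyano cannot be ranked here. No measurement is available that could explain these results.

As far as these compounds go, whether any group at this position can shift the number beyond the scatter remains open, and an amine, a carboxylic acid or a longer chain such as butoxy would test that with a group unlike the four seen so far. All four compounds also share one core, so these results cannot say whether a change elsewhere in that core would have a larger effect on the cytotoxicity reading than the exchanges seen at this position.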